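Methyl on the fused ring core: a small step

The source may report more compounds than this note shows. Statements on the series, on what has been measured and on what is new or still open speak of the compounds shown alone.

Among the three compounds measured so far in a functional assay on the whole organism with Mus musculus as the target, in the maximal electroshock model (on this read-out higher numbers stand for an effect only at larger amounts of compound and lower numbers for an effect already at smaller amounts), compound 2 `Cc1nn2cnnc2cc1Cc1ccccc1` gives 9.5 mg/kg. That places it second highest of the three numbers: compound 3 `Cc1nn2cnnc2cc1Cc1ccccc1Cl` lies closest, with 6 mg/kg, and the step of a 1.6-fold lower number from compound 2 to compound 3 (0.20 log units; within the scatter) stays inside the usual scatter; compound 1 `Cc1nn2c(-c3ccccc3)nnc2cc1Cc1ccccc1` lies furthest away, with 108 mg/kg.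

Compound 4 `Cc1nn2c(C)nnc2cc1Cc1ccccc1` differs from compound 2 by methyl in place of hydrogen on an aromatic carbon. Among the measured compounds shown here, the one measured step that bears on this carbon is an 11-fold lower number from compound 1 to compound 2 (1.06 log units; beyond the scatter), a large change, though there the group that left was phenyl, not methyl. Compound 3 adds nothing on this point, as its chloro sits on the other ring. A methyl is a single carbon, so only a modest part of that large step is expected to reappear in this assay, pointing toward a somewhat higher number, possibly none beyond the scatter.

For compound 4, the estimated value in this assay is 15 mg/kg, within a range from 6 mg/kg to 40 mg/kg, which is expected to amount to a 1.6-fold higher number from compound 2 to compound 4 (0.20 log units; within the scatter).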

Compound 4, dose for half-maximal effect: 26 mg/kg
The estimate for compound 4 lay 1.7-fold (0.24 log units) below the measured number, and the stated range covers the measured number.
By their numbers in this assay, from the lowest: compounds 3 and 2 (each within the scatter of the next); then compound 4; then compound 1.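

Even a single carbon counts at this position, the carbon of the five-membered aromatic ring that lies between two ring nitrogen atoms. In this assay, methyl in place of hydrogen gives a 2.7-fold higher number from compound 2 to compound 4 (0.44 log units; beyond the scatter), a modest step but one beyond the scatter. Methyl in place of phenyl gives a 4.2-fold lower number from compound 1 to compound 4 (0.62 log units; beyond the scatter), so across these three compounds the number rises in the order hydrogen, methyl, phenyl, and nothing shown explains that order.

As far as these compounds go, it remains open whether the same order would hold for a longer chain such as propyl, or how an amine or a carboxylic acid on this carbon would fit in. From the compounds shown here alone, it is also open whether methyl here would have a similar effect in compound 3, which carries a chloro group.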